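This account rests on a few compounds, and the source may have more. Where it says the series, first, only, none or still open, it means among the compounds named here.

Compound 2 `CCc1nncn1-c1ccc(OCc2ccccc2F)cc1` gives 21.2 mg/kg in a functional assay on the whole organism (strain C57B/6) with Mus musculus as the target, in the maximal electroshock model; on this read-out lower numbers stand for an effect already at smaller amounts and higher numbers for an effect only at larger amounts of compound. It stands together with compound 1 `CCc1nncn1-c1ccc(OCc2ccc(F)cc2)cc1`, which gives 22.8 mg/kg in this assay, since a 1.1-fold lower number from compound 1 to compound 2 (0.03 log units; within the scatter). Compound 3 `CCCOc1ccc(-n2cnnc2CC)cc1` reaches only a limit of this assay, > 100 mg/kg. From that follow an at least 4.7-fold higher number from compound 2 to compound 3 (0.67 log units; beyond the scatter) and an at least 4.3-fold higher number from compound 1 to compound 3 (0.64 log units; beyond the scatter), both ending at the limit of > 100 mg/kg in this assay, at which 1 of the 3 values shown sits. Compound 4 `CCCCCCCCOc1ccc(-n2cnnc2CC)cc1` differs from compound 2 in one place: heptyl in place of 2-fluorophenyl on a saturated chain carbon bound to an oxygen on an aromatic ring. The two steps toward compound 3, where a chain without a ring also entered, bear on this change; both were at least modest toward higher numbers, so a step beyond the scatter toward a higher number is expected for compound 4, although heptyl is longer than ethyl and the size remains uncertain. Compound 4 is therefore estimated at 60 mg/kg, with a range from 25 mg/kg to 200 mg/kg. The expected step is a 2.8-fold higher number from compound 2 to compound 4 (0.45 log units; beyond the scatter).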

Compound 4, dose for half-maximal effect: 8.8 mg/kg
Estimate against measurement, compound 4: 6.8-fold (0.83 log units) above; measured number below the stated range.
By their numbers in this assay, from the lowest: compound 4; then compounds 2 and 1 (each within the scatter of the next). At a limit, above all of these: compound 3.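

In this assay, a ring on the saturated chain carbon bound to an oxygen on an aromatic ring is not needed for a low number: heptyl gives a 2.4-fold lower number from compound 2 to compound 4 (0.38 log units; beyond the scatter) and a 2.6-fold lower number from compound 1 to compound 4 (0.41 log units; beyond the scatter). Chain length matters at this place, with an at least 11-fold lower number from compound 3 to compound 4 (1.05 log units; beyond the scatter), so ethyl did not stand for every chain. Compound 3 stands at a limit, so that step is only a bound: the limit of > 100 mg/kg in this assay, at which 1 of the 4 values shown sits.

On these data alone, whether a chain longer than heptyl lowers the number further, or a chain ending in an amine or a carboxylic acid preserves it, stays open. As far as these compounds go, how the number runs between ethyl and heptyl stays open too.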